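The compounds below may be only part of what the source reports. "The series", "measured", "known", "first", "only" and "open" are said of these compounds alone.

In a functional assay on A549 cells (Homo sapiens) for antiproliferative activity, read by MTT assay, with a stated time of 48 h (a lower number here means a stronger inhibitor, a higher number a weaker inhibitor), compound 1 `O=C(/C=C\Nc1ccc(C(F)(F)F)cc1)c1cn(-c2ccccc2)nc1-c1ccccc1` gives only a limit, > 50000 nM, not a number. Compound 2 `COc1cc(N/C=C\C(=O)c2cn(-c3ccccc3)nc2-c2ccccc2)cc(OC)c1OC` differs from compound 1 in more than one place, and the difference between the two cores is not broken down here. Among the measured compounds shown here, compound 2 is the one compound with a real number: in this assay compound 2 gives 6340 nM. Compound 3 `O=C(/C=C\Nc1ccc(C(F)(F)F)cc1)c1cn(-c2ccccc2)nc1-c1ccc(F)cc1` comes from compound 1 by fluoro in place of hydrogen on an aromatic carbon, and in this assay compound 3 also gives only a limit, > 50000 nM. Because two of the three results sit at the limit of > 50000 nM in this assay, at which 2 of the 3 values shown sit, the step from compound 1 to compound 3 is a step that the two limits leave unreadable from compound 1 to compound 3; with a limit at both ends, its size stays hidden.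

For the measured compounds named here, compound 4 `COc1cc(N/C=C\C(=O)c2cn(-c3ccccc3)nc2-c2ccc(F)cc2)cc(OC)c1OC` comes from compound 2 by fluoro in place of hydrogen on an aromatic carbon, the same change made on the same place as the one from compound 1 to compound 3. This time the starting compound has a number, so the step can be seen. The earlier step gives no size to lean on, so the expectation rests only on the smallness of the change itself and on the measured value of compound 2. I expect the step from compound 2 to compound 4 to stay within the usual scatter, a 1.2-fold lower number from compound 2 to compound 4 (0.06 log units; within the scatter), since a step that the two limits leave unreadable from compound 1 to compound 3 offers no sign of a large move in either direction. In this assay compound 4 is therefore estimated at about 5500 nM, most likely between 2000 nM and 15000 nM.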

Compound 4, half-maximal inhibitory concentration: 9350 nM
For compound 4 the middle estimate is 1.7-fold (0.23 log units) below the measured one, and the stated range covers the measured number.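

In this assay, replacing hydrogen with fluoro, which turns phenyl into 4-fluorophenyl, gives a 1.5-fold higher number from compound 2 to compound 4 (0.17 log units; within the scatter), so on the core of compound 2 this change has no effect that can be told apart from the ordinary spread of repeated measurements. The same change on the core of compound 1 cannot be read at all, because compound 1 and compound 3 each give only a limit and not a number: the limit of > 50000 nM in this assay, at which 2 of the 4 values shown sit. The series therefore offers one readable case of this change, which shows that it can be made on one core without a clear shift in the result, but it does not show that the change carries over from one core to the other, since that would take a readable step on both.

The compounds shown have only hydrogen or fluoro at this place, so it remains open whether a larger or differently built group there, such as chloro, an amine or a carboxylic acid, would move the number beyond the scatter. As far as these compounds go, it also remains open whether a core that gives a number at both ends of the step would respond to fluoro as the core of compound 2 does.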